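Swapping the aryl group on the aromatic nitrogen

The source may report more compounds than this note shows. Statements on the series, on what has been measured and on what is new or still open speak of the compounds shown alone.

Compound 1 `O[C@H](COCCOC[C@@H](O)Cc1cn(-c2ccc3c(c2)OCCO3)nn1)Cc1ccc(-c2ccccc2)cc1`, compound 2 `O[C@H](COCCOC[C@@H](O)Cc1cn(Cc2ccc(C(F)(F)F)cc2)nn1)Cc1ccc(-c2ccccc2)cc1` and compound 3 `O[C@H](COCCOC[C@@H](O)Cc1c[nH]nn1)Cc1ccc(-c2ccccc2)cc1` share one core and differ only in what sits on the aromatic nitrogen. In a functional assay on SGC-7901 cells (Homo sapiens) for inhibition, read by MTT assay, with a stated time of 72 h (on this read-out higher numbers stand for weaker inhibition of growth and lower numbers for stronger inhibition of growth), compound 1 gives 6400 nM. In this assay compound 2 gives 8700 nM, which sits alongside compound 1, since a 1.4-fold higher number from compound 1 to compound 2 (0.13 log units; within the scatter) cannot be separated from repeat variation. For compound 3 this assay reports only a limit, > 100000 nM, and not a number (the limit of > 100000 nM in this assay, at which 1 of the 3 values shown sits). Stripping the substituent to hydrogen is costly: an at least 15-fold higher number from compound 1 to compound 3 (1.19 log units; beyond the scatter) and an at least 11-fold higher number from compound 2 to compound 3 (1.06 log units; beyond the scatter).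

Compound 4 `O[C@H](COCCOC[C@@H](O)Cc1cn(Cc2cccc(-c3ccccc3)c2)nn1)Cc1ccc(-c2ccccc2)cc1` has not yet been measured. It is related to compound 2 by 3-phenylphenyl in place of 4-(trifluoromethyl)phenyl on a saturated chain carbon bound to an aromatic nitrogen. For the measured compounds named here, the only step that bears on such an exchange of one aryl-type group for another is the small one between compound 1 and compound 2, which stayed within the scatter; the two large steps describe removal of the group altogether, which compound 4 does not undergo. The expectation is therefore a step of about a 1.3-fold lower number from compound 2 to compound 4 (0.13 log units; within the scatter), that is no change beyond the scatter. Compound 4 is estimated at 6500 nM in this assay, with a range from 2500 nM to 17000 nM.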

Compound 4, concentration for 50% growth inhibition: 10600 nM
Compound 4: middle estimate off by 1.6-fold (0.21 log units), on the low side; measured number inside the range.
By their numbers in this assay, from the lowest: compounds 1, 2 and 4 (each within the scatter of the next). At a limit, above all of these: compound 3.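

In this assay the exchange gives a 1.2-fold higher number from compound 2 to compound 4 (0.09 log units; within the scatter), so 3-phenylphenyl and 4-(trifluoromethyl)phenyl cannot be told apart when they sit on a saturated chain carbon bound to an aromatic nitrogen. The earlier compounds had shown this position carrying only 2,3-dihydro-1,4-benzodioxin-6-yl and 4-(trifluoromethyl)benzyl, whereas compound 4 shows that it also accepts a group with 2 six-membered aromatic rings of carbon only, 12 heavy atoms and no fluorine, without any change beyond the scatter. Nothing on record bears on why the two groups read alike, so the result stands as an observation without an explanation.

The compounds shown leave open whether the second phenyl ring matters where it sits, since 3-phenylphenyl is the only such arrangement here and 4-phenylphenyl does not appear among them. They also leave open whether an amine or a carboxylic acid on the aromatic ring, or a longer chain in place of the single saturated carbon bound to the aromatic nitrogen, would keep the numbers in this same range.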